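The compounds below may be only part of what the source reports. "The series", "measured", "known", "first", "only" and "open" are said of these compounds alone.

Two compounds share one core, a sulfur-linked saturated chain and a halogen-bearing phenyl group at the far end. Compound 1 `Cn1c(Cc2nn(C)c(=O)c3ccccc23)nnc1SCCCCCC(=O)Nc1ccc(Cl)cc1Cl` and compound 2 `Cn1c(Cc2nn(C)c(=O)c3ccccc23)nnc1SCCCCCCCCCCC(=O)Oc1ccc(Cl)cc1Cl` have both been measured in an assay on isolated protein (Mus musculus) for inhibition of IL15-IL15 receptor (Homo sapiens), read by resazurin assay, with stated times of 30 min and 2.5 days; on this read-out higher numbers stand for weaker inhibition and lower numbers for stronger inhibition. In this assay compound 1 gives 4100 nM, the lowest of the two numbers shown, while compound 2 gives 8700 nM, a higher number whose gap from compound 1 lies beyond the usual scatter of this kind of measurement. Compound 2 carries a longer chain and an ester link in place of the amide.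

Compound 3 `Cn1c(Cc2nn(C)c(=O)c3ccccc23)nnc1SCCCCCCCC(=O)Nc1ccc(I)cc1` has not yet been measured in this assay. It differs from compound 1 in one place: 2-((4-iodophenyl)carbamoyl)ethyl in place of (2,4-dichlorophenyl)carbamoyl on a saturated chain carbon, five bonds along the chain from a sulfur. The chain between the sulfur and the carbonyl thus grows, and the ring carries one iodine rather than two chlorines. Among the measured compounds shown here, no measured pair isolates this change, so the expected step rests only on the two values shown, where the longer-chained compound 2 sits at the higher number 8700 nM.

The step of a 1.5-fold higher number from compound 1 to compound 3 (0.17 log units; within the scatter) is estimated to be small and toward a weaker result, possibly within the scatter. Compound 3 is expected to give about 6000 nM, with a likely range from 2000 nM to 18000 nM.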

Compound 3, half-maximal inhibitory concentration: 1300 nM
For compound 3 the middle estimate is 4.6-fold (0.66 log units) above the measured one; measured number below the stated range.
By their numbers in this assay, from the lowest: compound 3; then compound 1; then compound 2.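

In this assay the swap of (2,4-dichlorophenyl)carbamoyl for 2-((4-iodophenyl)carbamoyl)ethyl, on a saturated chain carbon five bonds along the chain from a sulfur, gives a 3.2-fold lower number from compound 1 to compound 3 (0.50 log units; beyond the scatter) and so moves inhibition in the stronger direction. This position therefore accepts a longer chain and a ring with one iodine in place of two chlorines, and inhibition improves rather than being lost. The amide link is the same in both compounds, so this step shows that the chain and the halogens at the far end can change the result even when that link stays untouched.

The step joins two edits, so it cannot say whether the longer chain or the change of halogen carries it; a (2,4-dichlorophenyl)carbamoyl group on the longer chain of compound 3, or a 4-bromophenyl amide on that same chain, would begin to separate the two. No measurement shown here explains why the number fell, and the reason for the step remains unknown.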